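The compounds below may be only part of what the source reports. "The series", "measured", "known", "first", "only" and "open" are said of these compounds alone.

Measured in a functional assay on HL-60 cells (Homo sapiens) for antiproliferative activity, read by XTT assay, with a stated time of 72 h; a lower number here means a stronger inhibitor, a higher number a weaker inhibitor:
- Compound 1 `CSc1ncnc2c1c(-c1cccs1)cn2[C@@H]1O[C@H](CO)[C@@H](O)[C@H]1O`: 1130 nM
- Compound 2 `CNc1ncnc2c1c(-c1cccs1)cn2[C@@H]1O[C@H](CO)[C@@H](O)[C@H]1O`: > 20000 nM

Compound 2 stands at a limit and not at a number: the limit of > 20000 nM in this assay, at which 1 of the 2 values shown sits. Its true value is therefore unknown.

Compound 3 `CNc1ncnc2c1c(I)cn2[C@@H]1O[C@H](CO)[C@@H](O)[C@H]1O` keeps the methylamino group of compound 2. The change is iodo in place of thiophen-2-yl on an aromatic carbon, which puts iodo in place of thiophen-2-yl on an aromatic carbon of a five-membered aromatic ring.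

Among the compounds with values here, the only measured step is an at least 17-fold higher number from compound 1 to compound 2 (1.24 log units; beyond the scatter). That step is large, but it concerns methylamino in place of methylsulfanyl, not the group that changes now. Within the data shown here, no measured step covers an exchange of thiophen-2-yl for iodo, so the data give no direct size for it. Compound 3 retains the methylamino group introduced in that large step, so weak activity remains the expectation. From a limit, a measurable change in this assay can only run towards a lower number, and compound 3 may well stay at the limit.

The expected change is an at least 3.3-fold lower number from compound 2 to compound 3 (0.52 log units; beyond the scatter). For compound 3, the estimated value is 6000 nM, with an expected range from 500 nM to 20000 nM.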

Compound 3, half-maximal inhibitory concentration: > 20000 nM
Compound 3 was reported as a limit; the forecaster's own chance of this, stated with the estimate: 40%; at least 3.3-fold (0.52 log units) between middle value and limit.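

In this assay, compound 3 gives > 20000 nM, which is a limit and not a number. No step from compound 2 to compound 3 can be read, because both compounds stand at the same limit: the limit of > 20000 nM in this assay, at which 2 of the 3 values shown sit.

The compounds shown leave open whether iodo or thiophen-2-yl gives the lower true value alongside the methylamino group.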